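Sulfamoyl to imidazolyl on the anilino ring of compound 2

The compounds below may be only part of what the source reports. "The series", "measured", "known", "first", "only" and "open" are said of these compounds alone.

Compound 2 `NS(=O)(=O)c1ccc(Nc2nccc(-c3cccnc3)n2)cc1` gives 200 nM in a functional assay for inhibition, with Homo sapiens as the target (a lower number here means a stronger inhibitor, a higher number a weaker inhibitor), the lowest number of the three measured. Compound 1 `CN(C)c1cccc(Nc2nccc(-c3cccs3)n2)c1` gives 2400 nM and compound 3 `NS(=O)(=O)c1ccc(Nc2nccc(-c3ccncc3)n2)cc1` gives 5100 nM; the single-point step a 26-fold higher number from compound 2 to compound 3 (1.41 log units; beyond the scatter) shows that the heteroaryl arm alone can move this assay strongly.

Compound 4 `c1cncc(-c2ccnc(Nc3ccc(-n4ccnc4)cc3)n2)c1` keeps the pyridin-3-yl arm of compound 2 and changes the other end: 1H-imidazol-1-yl in place of sulfamoyl on an aromatic carbon. Among the measured compounds shown here, no measured pair isolates this exchange; compound 1 carries a different amine on its anilino ring but also a different heteroaryl arm, so its value cannot be attributed to either change. For the measured compounds named here, the only directly comparable step concerns the heteroaryl arm, not this position, so the expectation rests on the absence of evidence rather than on a trend.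

With the hydrogen-bond donor of the sulfamoyl gone, a moderate weakening is expected, a 4.0-fold higher number from compound 2 to compound 4 (0.60 log units; beyond the scatter), but with wide uncertainty. Compound 4 is estimated at 800 nM, within 200 nM to 3500 nM.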

Compound 4, half-maximal inhibitory concentration: 1300 nM
Beside the measured number, compound 4's estimate is 1.6-fold (0.21 log units) below it, and the stated range covers the measured number.
By their numbers in this assay, from the lowest: compound 2; then compounds 4 and 1 (each within the scatter of the next); then compound 3.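

In this assay, with the pyridin-3-yl arm held fixed, the exchange of sulfamoyl for 1H-imidazol-1-yl gives a 6.5-fold higher number from compound 2 to compound 4 (0.81 log units; beyond the scatter), so this position, and not only the heteroaryl arm, moves the number beyond the scatter. The exchange removes the hydrogen-bond donor of sulfamoyl and adds a five-membered aromatic ring in one step, so the two changes cannot be told apart, although compound 4 still gives 1300 nM without that donor. No measurement here accounts for the size of this step.

Going by these compounds, whether the step follows the loss of the donor or the arrival of the ring remains open, and a methylsulfonyl group or a carboxamide at the same place would bear on that question. Also open, on these data alone, is whether the step keeps its size with the pyridin-4-yl arm of compound 3.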